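The source may report more compounds than this note shows. Statements on the series, on what has been measured and on what is new or still open speak of the compounds shown alone.

Measured in a functional assay on K562 cells (Homo sapiens) for inhibition, read by MTT assay, with a stated time of 48 h; a lower number here means a stronger inhibitor, a higher number a weaker inhibitor:
Compound 1 `CC(=O)Nc1ccc(-c2cn([C@@H]3CN[C@H](C(=O)Nc4ccc(Cl)c(C(F)(F)F)c4)C3)nn2)cn1`: 8980 nM
Compound 2 `O=C(Nc1ccc(-c2cn([C@@H]3CN[C@H](C(=O)Nc4ccc(Cl)c(C(F)(F)F)c4)C3)nn2)cn1)C1CC1`: 8770 nM

Compound 1 and compound 2 stand level within the scatter. Compound 3 `C=CC(=O)Nc1ccc(-c2cn([C@@H]3CN[C@H](C(=O)Nc4ccc(Cl)c(C(F)(F)F)c4)C3)nn2)cn1` differs from compound 1 by one change: vinyl in place of methyl on a carbonyl carbon. Going by the values given here, the only measured step at this place, a 1.0-fold lower number from compound 1 to compound 2 (0.01 log units; within the scatter), puts cyclopropyl in place of methyl on a carbonyl carbon. That single step is weak evidence for vinyl, so no change beyond the scatter is expected, though with wide uncertainty. The expected step is a 1.2-fold lower number from compound 1 to compound 3 (0.08 log units; within the scatter). Compound 3 is estimated at 7500 nM, with an expected range of 3000 nM to 14000 nM.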

Compound 3, half-maximal inhibitory concentration: 3860 nM
Estimate against measurement, compound 3: 1.9-fold (0.29 log units) above, and the stated range covers the measured number.
By their numbers in this assay, from the lowest: compound 3; then compounds 2 and 1 (each within the scatter of the next).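

In this assay, the group on this carbonyl carbon can shift the number after all: vinyl brings a 2.3-fold lower number from compound 1 to compound 3 (0.37 log units; beyond the scatter) and a 2.3-fold lower number from compound 2 to compound 3 (0.36 log units; beyond the scatter). Methyl and cyclopropyl stand level, so the earlier pair gave no sign that this position mattered, while vinyl separates from both by a modest step. Nothing measured here explains this difference. On these data alone, whether the double bond itself matters remains open, and ethyl, the saturated counterpart of vinyl, would test that. As far as these compounds go, how a longer chain or an amine at this place would compare also remains open.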